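Swapping Amino for Isopropyl on a Uracil-Bearing Phenyl Ether

The compounds below may be only part of what the source reports. "The series", "measured", "known", "first", "only" and "open" are said of these compounds alone.

Compound 1 `Nc1ccc(OCCCCCn2ccc(=O)[nH]c2=O)cc1` was tested in an ADME assay on HEL cells (Homo sapiens) for cytotoxicity, read by microscopy; a higher number here means that more compound is tolerated, a lower number that less compound is tolerated. In this assay compound 1 stops at the limit of measurement, giving > 100000 nM, which is a limit rather than a true number. A second member of the set, compound 2 `O=c1ccn(CCCCCCCCOc2ccc(Br)cc2)c(=O)[nH]1`, also reaches only a limit, with compound 2 giving >= 100000 nM. Compound 1 therefore stands at the first of the two limits recorded (the limit of > 100000 nM in this assay, at which 1 of the 2 values shown sits), and compound 2 at the second (the limit of >= 100000 nM in this assay, at which 1 of the 2 values shown sits); no ordering of the two can be drawn from limits alone.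

The unmeasured compound 3 `CC(C)c1ccc(OCCCCCn2ccc(=O)[nH]c2=O)cc1` differs from compound 1 in one change: isopropyl in place of amino on an aromatic carbon. With both known values resting at a limit, no step beyond the usual scatter is expected in either direction; for compound 3 the estimated step is a number no higher from compound 1 to compound 3 (the limit leaves the size open). Compound 3 is thus expected to give about 100000 nM, within 30000 nM to 200000 nM.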

Compound 3, minimum cytotoxic concentration: 100000 nM
Beside the measured number, compound 3's estimate shows no gap at the digits printed, within the range that was stated.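

For the compounds shown here, at this position, on an aromatic carbon para to a large group, compound 3 gives 100000 nM in this assay, the first value in the set that is a number and not a limit. Isopropyl, with its 3 carbon atoms and 0 hydrogen-bond donors, can therefore take the place of amino and still leave a compound with a measurable tolerated concentration, the change giving a number no higher from compound 1 to compound 3 (the limit leaves the size open). The size of that step cannot be read, because compound 1 rests at a limit: the limit of > 100000 nM in this assay, at which 1 of the 3 values shown sits.

The compounds shown leave open whether this swap changes tolerance a little, a lot or not at all. They also leave open how a carboxylic acid or a nitrile would behave at the same position on the core of compound 1.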